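This account rests on a few compounds, and the source may have more. Where it says the series, first, only, none or still open, it means among the compounds named here.

Measured compounds:
compound 1, `CC(C)[C@@H](O)C(=O)c1c[nH]c2ccccc12`, > 10000 nM
compound 2, `CC(C)(O)C(=O)Cc1cn([C@@H]2O[C@H](CO)[C@@H](O)[C@H](O)[C@H]2O)c2ccccc12`, > 10000 nM

In a functional assay on A549 cells (Homo sapiens) for cytotoxicity, read by MTT assay (a higher number here means a weaker inhibitor, a lower number a stronger inhibitor), compound 1 gives only a limit, > 10000 nM. In this assay compound 2 likewise gives only a limit, > 10000 nM. Compound 2 therefore stands at the limit of > 10000 nM in this assay, at which 2 of the 2 values shown sit, and no number places it within the measurable range. Compound 3, `CC(C)(O)[C@@H](O)Cc1cn([C@@H]2O[C@H](CO)[C@@H](O)[C@H](O)[C@H]2O)c2ccccc12`, differs from compound 2 by 1,2-dihydroxy-2-methylpropyl in place of (1-hydroxy-1-methylethyl)carbonyl on a saturated chain carbon bound to an aromatic carbon. Within the data shown here, no measured step informs this change, so the step that the limit leaves unreadable from compound 2 to compound 3 is expected to be none beyond the scatter. Compound 3 is accordingly estimated at 20000 nM, ranging from 5000 nM to 100000 nM, most likely again reported as a limit.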

Compound 3, half-maximal inhibitory concentration: > 10000 nM
Compound 3 ended at the assay's limit; the forecaster's own chance of this, stated with the estimate: 85%; the middle value does not contradict the limit.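

No step from compound 2 to compound 3 can be read, because both compounds give only a limit: the limit of > 10000 nM in this assay, at which 3 of the 3 values shown sit.

The compounds shown leave open how strongly any of them acts in this assay, and whether the change from compound 2 to compound 3 matters at all.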